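The source may hold more compounds than are shown below. What is called first, only, known or untested is meant among the compounds shown, and "the series" means these compounds.

Measured compounds:

compound 1, `CC(=O)c1ccc(NC(=O)c2cc3ccccc3[nH]2)cc1` — > 100000 nM
compound 2, `O=C(c1ccccc1)c1cccc(NC(=O)c2cc3ccccc3[nH]2)c1` — > 100000 nM
compound 3, `CC(O)c1cccc(NC(=O)c2cc3ccccc3[nH]2)c1` — > 100000 nM

All three share the same core and differ only in the group carried on the outer aromatic ring. In a functional assay on K562 cells (Homo sapiens) for inhibition, read by MTT assay, with a stated time of 24 h (a higher number here means a weaker inhibitor, a lower number a stronger inhibitor), compound 1 gives > 100000 nM, and this is a limit of the assay rather than a measured number. Compound 2 gives > 100000 nM, again a limit. Compound 3 gives > 100000 nM, also a limit. Among the compounds with values here, because every value sits at the limit of > 100000 nM in this assay, at which 3 of the 3 values shown sit, the one comparison between measured compounds, a step that the two limits leave unreadable from compound 2 to compound 3, cannot be read: two limits say nothing about how far apart the true values lie.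

Compound 4, `O=C(Nc1ccc(C(O)c2ccccc2)cc1)c1cc2ccccc2[nH]1`, is still to be measured in this assay. It differs from compound 1 by hydroxy(phenyl)methyl in place of acetyl on an aromatic carbon. Within the data shown here, no measured step bears on this change in a readable way; the acetyl, benzoyl and 1-hydroxyethyl variants all stopped at the same limit, so the data give no direction for the move to hydroxy(phenyl)methyl. On that basis compound 4 is expected to behave like its neighbours, with the step that the limit leaves unreadable from compound 1 to compound 4 expected to stay within the scatter, and most likely to return only a limit. The estimate for compound 4 is 120000 nM, with a range from 40000 nM to 400000 nM.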

Compound 4, half-maximal inhibitory concentration: > 100000 nM
Compound 4: only a limit was reported (the forecaster's own chance of this, stated with the estimate: 80%); the middle value does not contradict the limit.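

Compound 4 gives > 100000 nM in this assay, which is a limit and not a number. The change from compound 1 to compound 4 therefore cannot be sized, since both values are limits: the limit of > 100000 nM in this assay, at which 4 of the 4 values shown sit.

The compounds shown leave open how strong each one truly is, and whether any group on the outer aromatic ring would give a readable value in this assay.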